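Benzylamide substituent change from compound 2 to compound 4

This account rests on a few compounds, and the source may have more. Where it says the series, first, only, none or still open, it means among the compounds named here.

Measured so far:
compound 1 `Cc1ccc(CNC(=O)c2nc(-c3ccc(F)cc3)n(CC[C@@H](O)C[C@@H](O)CC(=O)O)c2C2CC2)cc1` — 178 nM
compound 2 `COc1ccc(CNC(=O)c2nc(-c3ccc(F)cc3)n(CC[C@@H](O)C[C@@H](O)CC(=O)O)c2C2CC2)cc1` — 6400 nM
compound 3 `CC(C)c1c(C(=O)NCc2ccccc2)nc(-c2ccc(F)cc2)n1CC[C@@H](O)C[C@@H](O)CC(=O)O` — 3030 nM

In a functional assay on L6 cells (Rattus norvegicus) for inhibition, read by scintillation counting, with a stated time of 3 h (on this read-out higher numbers stand for weaker inhibition and lower numbers for stronger inhibition), compound 2 stands at the highest number of the three. Compound 3 gives 3030 nM, a somewhat lower number, and compound 1 gives 178 nM, the lowest by a wide margin. Compound 4 `Cc1cccc(CNC(=O)c2nc(-c3ccc(F)cc3)n(CC[C@@H](O)C[C@@H](O)CC(=O)O)c2C2CC2)c1` differs from compound 2 by 3-methylphenyl in place of 4-methoxyphenyl on a saturated chain carbon bound to an amide-type nitrogen. Within the data shown here, the single step that bears on this change is a 36-fold higher number from compound 1 to compound 2 (1.56 log units; beyond the scatter): methoxy in place of methyl brought a large rise. Compound 4 returns to a methyl group, but as 3-methylphenyl rather than the methyl-bearing ring of compound 1, so the full reverse of that step cannot be assumed. Compound 3, with an unsubstituted benzyl group and a different core, lies near compound 2, which shows that the plain ring gives only weak inhibition here. The expectation is therefore a clear fall, a 9.1-fold lower number from compound 2 to compound 4 (0.96 log units; beyond the scatter), smaller than the measured rise from compound 1 to compound 2. Compound 4 is estimated at 700 nM, within 150 nM to 3000 nM.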

Compound 4, half-maximal inhibitory concentration: 532 nM
For compound 4 the middle estimate is 1.3-fold (0.12 log units) above the measured one, within the range that was stated.
By their numbers in this assay, from the lowest: compound 1; then compound 4; then compound 3; then compound 2.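

In this assay, the step of a 12-fold lower number from compound 2 to compound 4 (1.08 log units; beyond the scatter) shows that the large loss seen with 4-methoxyphenyl is recovered to a great extent by 3-methylphenyl, though this change alters both the group and its place on the ring. The step of a 3.0-fold higher number from compound 1 to compound 4 (0.48 log units; beyond the scatter) isolates the place of the methyl group: with the group unchanged, the number still moves beyond the scatter, modestly, and 4-methylphenyl keeps the lower number. The data shown offer no explanation for either step.

From the compounds shown here alone, how much of the first step belongs to the exchange of methoxy for methyl and how much to the shift in place remains open. Also open, going by these compounds, is how ethyl, fluoro, an amine or a carboxylic acid on the phenyl ring would read.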